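The compounds below may be only part of what the source reports. "The series", "measured", "known", "first", "only" and "open" are said of these compounds alone.

Compound 1 `C/N=C(/NC#N)NCCCCCn1nc(-c2ccccc2)c(C)cc1=O` — in a functional assay on the whole organism (stomach) with Rattus norvegicus as the target (on this read-out higher numbers stand for an effect only at larger amounts of compound and lower numbers for an effect already at smaller amounts), compound 1 gives > 100 mg/kg, a limit of the assay rather than a number.
Compound 2 `CC/N=C(\S)NCCCn1nc(-c2ccccc2)ccc1=O` — in this assay compound 2 gives > 100 mg/kg, again a limit.
Compound 3 `C/N=C(/NC#N)NCCCCn1nc(Nc2ccccc2)ccc1=O` — in this assay compound 3 gives > 100 mg/kg, again a limit.

Compound 2 therefore stands at the limit of > 100 mg/kg in this assay, at which 3 of the 3 values shown sit; nothing in the shown numbers sets it apart from compound 1 or compound 3, and no pair of measured compounds differing in one place is available, so no measured step can be read from these three.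

The account follows the change from compound 2 to compound 4 `CN(C)/C(=N/CCCn1nc(-c2ccccc2)ccc1=O)NC#N`. The change is a group of 8 heavy atoms (4 carbon, 4 nitrogen; no ring) in place of a group of 6 heavy atoms (3 carbon, 2 nitrogen, 1 sulfur; no ring), on a saturated chain carbon, three bonds along the chain from an aromatic nitrogen.

Among the measured compounds shown here, with no measured step to lean on, and with every value shown sitting at the limit, the expectation for compound 4 rests only on that shared position. Compound 4 is expected to give a dose for half-maximal effect of about 100 mg/kg, with a range from 30 mg/kg to 300 mg/kg. The step of a number no higher from compound 2 to compound 4 (the limit leaves the size open) is thus expected to be none beyond the scatter, and the most likely outcome is that compound 4 also returns only a limit.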

Compound 4, dose for half-maximal effect: 53 mg/kg
Compound 4: middle estimate off by 1.9-fold (0.28 log units), on the high side; measured number inside the range.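

Among the compounds shown here, at this place, on a saturated chain carbon, three bonds along the chain from an aromatic nitrogen, the exchange of groups gives the first true number in this assay, something the earlier compounds could not show: the limit of > 100 mg/kg in this assay, at which 3 of the 4 values shown sit. On these data alone, the exchange amounts to an at least 1.8-fold lower number from compound 2 to compound 4 (0.27 log units; that floor lies within the scatter), and since the starting value is only a limit, this is a floor on the step and its real size stays unknown. What the pair does show is that the read-out at this position is not fixed at the limit, and that the group of 8 heavy atoms (4 carbon, 4 nitrogen; no ring) with its triple bond can bring an effect into the range of doses tested, where the group of 6 heavy atoms (3 carbon, 2 nitrogen, 1 sulfur; no ring) gave none that could be put as a number.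

With a single pair, the compounds shown leave open which part of the entering group carries the step. They also leave open whether a simple amine or a carboxylic acid at the same place would return a number or another limit.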